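The source may hold more compounds than are shown below. What is called first, only, known or untested is meant among the compounds shown, and "the series" means these compounds.

Measured in a functional assay on HCT-116 cells (Homo sapiens) for antiproliferative activity, read by MTT assay, with a stated time of 72 h; on this read-out higher numbers stand for weaker inhibition and lower numbers for stronger inhibition:

- Compound 1 `O=C1COc2ccc(-c3cccc(NS(=O)(=O)c4ccc(F)cc4)c3)cc2N1c1ccc(Cl)cc1`: 23900 nM
- Compound 2 `O=C1COc2ccc(-c3cccc(NS(=O)(=O)c4ccc(F)cc4)c3)cc2N1c1ccccc1`: > 40000 nM (a limit of the assay, not a number)
- Compound 3 `O=C1COc2ccc(-c3cccc(NS(=O)(=O)c4ccc(F)cc4)c3)cc2N1C1CCCCC1`: 18300 nM

Only two of these compounds have an actual number, and those two sit close together: a 1.3-fold lower number from compound 1 to compound 3 (0.12 log units; within the scatter). Compound 3 therefore shares the low end of this small set with compound 1. It stands clearly apart only from the phenyl compound: an at least 2.1-fold lower number from compound 2 to compound 3 (0.33 log units; beyond the scatter).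

Compound 4 `O=C1COc2ccc(-c3cccc(NS(=O)(=O)c4ccc(F)cc4)c3)cc2N1c1ccc(F)cc1` keeps the shared core and carries 4-fluorophenyl in place of cyclohexyl on an amide-type nitrogen in a ring. Its new group is an aromatic ring, as in compound 1 and compound 2, so the two steps to compound 3 are the nearest guides. Removing the chloro group also bears on it: an at least 1.6-fold higher number from compound 1 to compound 2 (0.22 log units; that floor lies within the scatter). Compound 4 is expected to fall near or somewhat past compound 1, toward the limit seen for compound 2. A small rise in the number is expected, with the estimated step being a 1.6-fold higher number from compound 3 to compound 4 (0.21 log units; within the scatter) and no large change in this assay anticipated. For compound 4 the estimate is 30000 nM, with an expected range from 17000 nM to 50000 nM as the likely span.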

Compound 4, half-maximal inhibitory concentration: > 40000 nM
Compound 4: a limit, no number; the forecaster's own chance of this, stated with the estimate: 35%; at least 1.3-fold (0.12 log units) between middle value and limit.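

In this assay, placing 4-fluorophenyl instead of cyclohexyl on the amide-type nitrogen gives an at least 2.1-fold higher number from compound 3 to compound 4 (0.33 log units; beyond the scatter), which makes this the second aromatic group, after the phenyl of compound 2, to stand clearly apart from cyclohexyl at this position; compound 1 goes against any general rule about aromatic groups here, as its 4-chlorophenyl group stays within the scatter of compound 3. Exchanging chloro for fluoro on the aromatic carbon gives an at least 1.6-fold higher number from compound 1 to compound 4 (0.22 log units; that floor lies within the scatter), so these compounds do not establish a real difference between the two halogens. Compound 4, like compound 2, gives a limit and not a number, so the step between them cannot be read and the other two steps are only floors: the limit of > 40000 nM in this assay, at which 2 of the 4 values shown sit.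

On these data alone, it remains open whether a plain chain such as n-butyl, or a ring carrying an amine such as piperidinyl, would behave like cyclohexyl on this nitrogen. As far as these compounds go, it is also open how a methoxy group or a carboxylic acid in place of the chloro group of compound 1 would compare.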